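Dropping the nitrile tail from a phenol acetophenone ether

This account rests on a few compounds, and the source may have more. Where it says the series, first, only, none or still open, it means among the compounds named here.

The series rests on one shared core, varied only at the ether chain. In an assay on isolated protein for inhibition of leukotriene B4 receptor 1 (Homo sapiens), tested at 10 uM (on this read-out higher numbers stand for more inhibition at the one concentration tested (going by the name of the read-out) and lower numbers for less inhibition), compound 1 `CCc1cc(C(C)=O)c(O)cc1OCCCCCCC#N` gives 103% and compound 2 `C=CCc1cc(C(C)=O)c(O)cc1OCCCCCCCC#N` gives 88%; compound 2 thus stands lowest of the two numbers, with compound 1 higher by a gap beyond the scatter. Compound 3 `C=CCc1cc(C(C)=O)c(O)cc1OCCCCC` is not yet measured; it differs from compound 2 by hydrogen in place of 2-cyanoethyl on a saturated chain carbon, five bonds along the chain from an oxygen on an aromatic ring. Without a measured step for this kind of change, the size is uncertain, but a decrease is expected, estimated at a number 28 percentage points lower from compound 2 to compound 3 (beyond the scatter). For compound 3 the expected value in this assay is 60%, within 30% to 90%.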

Compound 3, a percentage reported as inhibition, at one concentration (the size of the read-out at that concentration, not a potency): 60%
The estimate for compound 3 equals the measured number at the digits printed; measured number inside the range.
By their numbers in this assay, from the lowest: compound 3; then compound 2; then compound 1.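

In this assay, for the compounds shown here, the change at this position gives a number 28 percentage points lower from compound 2 to compound 3 (beyond the scatter) and is the first measured step here. Compound 3 still reads 60% without any nitrile, so inhibition in this read-out does not depend on that group being present. No measurement on hand explains the step.

The step removes the nitrile and shortens the chain at once, and these two changes cannot be separated. From the compounds shown here alone, how a longer plain chain, or a carboxylic acid in place of the nitrile, would read remains open.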